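A few compounds are considered here, and "the series" means these few. Any claim that something is new, unique, unknown or untested is made for them only; others in the source may bear on it.

Of the compounds shown here, three have so far been tested in an ADME assay on Vero cells (Chlorocebus sabaeus) for cytotoxicity, read by MTT assay, with a stated time of 72 h; a higher number here means a weaker inhibitor, a lower number a stronger inhibitor. In this assay compound 1 `O=[N+]([O-])c1c[nH]c(-c2nnc(-c3ccc[nH]3)o2)c1` gives 227000 nM, compound 2 `COc1cccc(OC)c1-c1nnc(-c2cc([N+](=O)[O-])cn2C)o1` gives 177000 nM, and compound 3 `O=[N+]([O-])c1c[nH]c(-c2nnc(-c3cccs3)o2)c1` gives 418000 nM. Compound 3 therefore holds the highest of the three numbers; the nearest to it is compound 1, whose gap to compound 3 lies within the usual scatter of repeated measurements, while compound 2 lies furthest away, with a gap that goes beyond the scatter. Going by the values given here, the one single-change comparison among the measured compounds is a 1.8-fold higher number from compound 1 to compound 3 (0.27 log units; within the scatter), and that step itself was within the scatter.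

Compound 4 `O=[N+]([O-])c1c[nH]c(-c2nnc(-c3ccccc3)o2)c1` differs from compound 3 in one place: phenyl in place of thiophen-2-yl on an aromatic carbon. Among the compounds with values here, no measured pair shows exactly this exchange. The step that bears most on it is a 1.8-fold higher number from compound 1 to compound 3 (0.27 log units; within the scatter), which swapped one five-membered ring for another at the same position on the shared core and moved the number hardly at all. On that evidence, swapping in a six-membered ring of carbon only is expected to produce a step of a 1.2-fold lower number from compound 3 to compound 4 (0.08 log units; within the scatter), a change that would not stand out from the scatter. Compound 4 is accordingly expected to give about 350000 nM in this assay, most likely between 150000 nM and 800000 nM.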

Compound 4, half-maximal inhibitory concentration: 423000 nM
Compound 4: middle estimate off by 1.2-fold (0.08 log units), on the low side; low and high end bracket the measured number.
By their numbers in this assay, from the lowest: compounds 2, 1, 3 and 4 (each within the scatter of the next, the first and the last beyond it).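

In this assay this position on the shared core now carries three different rings, and the step of a 1.0-fold higher number from compound 3 to compound 4 (0.01 log units; within the scatter) shows that a six-membered aromatic ring of carbon only cannot be told apart from the five-membered thiophen-2-yl it replaces. The step of a 1.9-fold higher number from compound 1 to compound 4 (0.27 log units; within the scatter) lies within the scatter as well, so among compound 1, compound 3 and compound 4 neither the size of the ring nor the presence of a hetero atom in it gives a difference that can be read in these numbers. No measurement available here explains why these rings read alike.

All three groups at this position are single aromatic rings, so the compounds shown leave open whether a group of another kind, such as an amine, a carboxylic acid or a longer alkyl chain, would give a step beyond the scatter. They also leave open what a phenyl ring carrying a further group, such as methoxy, would do at this same place.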